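The compounds below may be only part of what the source reports. "The series", "measured", "known", "first", "only" and "open" are said of these compounds alone.

Measured so far in an assay on isolated protein for inhibition of Myc proto-oncogene protein (Homo sapiens), read by mobility shift assay, tested at 100 uM; a lower number here means less inhibition, a higher number more inhibition at the concentration tested (going by the name of the read-out):
- compound 1, `Cc1ccccc1Nc1ccc([N+](=O)[O-])c2nonc12`, gives 11%
- compound 2, `O=[N+]([O-])c1ccc(Nc2ccccc2Br)c2nonc12`, gives 39%

Among the compounds with values here, compound 2 stands highest of the two numbers in this assay; its nearest neighbour is compound 1, and the single measured step, a number 28 percentage points higher from compound 1 to compound 2 (beyond the scatter), runs from methyl to bromo on the aromatic carbon and lies beyond the scatter.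

Compound 3, `O=[N+]([O-])c1ccc(Nc2ccccc2O)c2nonc12`, is not yet measured. Its difference from compound 2 is hydroxy in place of bromo on an aromatic carbon. Within the data shown here, no measured step involves a hydroxy group, so the only bearing comes from the methyl-to-bromo step above, which shows that a change at this aromatic carbon can move the read-out by a modest amount. Among the measured compounds shown here, with no direct precedent for hydroxy, the expectation is a step of uncertain direction, most likely downward from the bromo value, estimated as a number 17 percentage points lower from compound 2 to compound 3 (beyond the scatter). Compound 3 is therefore expected to give about 22% in this assay, within a range from 2% to 45%.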

Compound 3, a percentage reported as inhibition, at one concentration (the size of the read-out at that concentration, not a potency): 13%
Estimate against measurement, compound 3: 9 percentage points above; measured number inside the range.
By their numbers in this assay, from the lowest: compounds 1 and 3 (each within the scatter of the next); then compound 2.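

In this assay hydroxy in place of bromo on this aromatic carbon, ortho to a large group, gives a number 26 percentage points lower from compound 2 to compound 3 (beyond the scatter) and hydroxy in place of methyl gives a number 2 percentage points higher from compound 1 to compound 3 (within the scatter) at the same carbon. Among the three groups now seen here, bromo alone stands apart, while hydroxy and methyl cannot be told apart in this read-out, so the position does not respond to every change of group. Nothing measured accounts for what sets bromo apart from the other two groups.

From the compounds shown here alone, whether the higher number belongs to bromo alone or extends to chloro or iodo remains open. Also open, going by these compounds, is where an amine or a methoxy group on this carbon would fall relative to the three groups seen so far.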